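From difluorophenyl to dichlorophenyl: estimating a cytotoxicity value

The source may hold more compounds than are shown below. What is called first, only, known or untested is meant among the compounds shown, and "the series" means these compounds.

In an ADME assay on MT4 cells (Homo sapiens) for cytotoxicity, read by MTT assay (a higher number here means that more compound is tolerated, a lower number that less compound is tolerated), compound 1 `Cc1ccc(C(=O)N(C(=S)OCCN2C(=O)c3ccccc3C2=O)c2ccc(Cl)cc2)cc1` gives > 100000 nM, which is a limit of the assay and not a number. Compound 2 `O=C1c2ccccc2C(=O)N1CCOC(=S)N(C(=O)c1ccc(F)cc1F)c1ccc(Cl)cc1` gives 52000 nM. Compound 3 `O=C1c2ccccc2C(=O)N1CCOC(=S)N(C(=O)c1c(F)cccc1F)c1ccc(Cl)cc1` gives 39000 nM. These last two values sit within the scatter of each other, as a 1.3-fold lower number from compound 2 to compound 3 (0.12 log units; within the scatter) shows, while an at least 2.5-fold lower number from compound 1 to compound 3 (0.40 log units; beyond the scatter) goes beyond it. Compound 4 `O=C1c2ccccc2C(=O)N1CCOC(=S)N(C(=O)c1c(Cl)cccc1Cl)c1ccc(Cl)cc1` differs from compound 3 by 2,6-dichlorophenyl in place of 2,6-difluorophenyl on a carbonyl carbon. For the measured compounds named here, no measured step makes this exact swap. The closest guide is the small 1.3-fold lower number from compound 2 to compound 3 (0.12 log units; within the scatter), so no step beyond the scatter is expected in this assay. The expected change is a 1.1-fold lower number from compound 3 to compound 4 (0.05 log units; within the scatter). For compound 4 the estimated value is 35000 nM, with an expected range of 13000 nM to 90000 nM.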

Compound 4, half-maximal cytotoxic concentration: 20000 nM
Estimate against measurement, compound 4: 1.8-fold (0.24 log units) above; measured number inside the range.
By their numbers in this assay, from the lowest: compounds 4, 3 and 2 (each within the scatter of the next, the first and the last beyond it). At a limit, above all of these: compound 1.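

Taken alone, the move from 2,6-difluorophenyl to 2,6-dichlorophenyl on this carbonyl carbon gives a 2.0-fold lower number from compound 3 to compound 4 (0.29 log units; within the scatter), so it cannot be told apart from repeat noise. Set against the 2,4-difluorophenyl compound, however, it gives a 2.6-fold lower number from compound 2 to compound 4 (0.41 log units; beyond the scatter), the only gap beyond the scatter between two plain numbers here. The step from the 4-methylphenyl compound is an at least 5.0-fold lower number from compound 1 to compound 4 (0.69 log units; beyond the scatter), and compound 1 holds a limit of the assay, not a number: the limit of > 100000 nM in this assay, at which 1 of the 4 values shown sits.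

The compounds shown leave open what a 2,6-dibromophenyl group would give in this place. The same holds for a phenyl ring carrying an amine or a carboxylic acid.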